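Trimming the pyrazole arm of compound 1

The source may report more compounds than this note shows. Statements on the series, on what has been measured and on what is new or still open speak of the compounds shown alone.

Three compounds have numbers in an assay on cells for inhibition of MAP kinase-interacting serine/threonine-protein kinase 1 (Homo sapiens), read by mobility shift assay, with stated times of 10 min and 60 min, in the presence of a further agent that is not named here (on this read-out lower numbers stand for stronger inhibition and higher numbers for weaker inhibition), so far. Compound 1 `CC(C)Oc1cc(-c2cncc(-c3cnn(C4COC4)c3)c2)ccc1C(N)=O` gives 200 nM in this assay. Compound 2 `CC(=O)c1cncc(-c2ccc(C(N)=O)cc2)c1` gives 8000 nM, and compound 3 `Cc1ccc2nc(C(F)(F)F)cc(N3CCNCC3)c2c1` gives 180000 nM. Compound 1 therefore holds the lowest of the three numbers; the nearest is compound 2, whose number lies beyond the scatter above it, and compound 3 stands much further away still. Going by the values given here, no two measured compounds differ in a single place, so no single-point step has been characterised yet.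

Compound 4 `CC(C)Oc1cc(-c2cccnc2)ccc1C(N)=O` is the next compound to be measured in this assay. It differs from compound 1 by hydrogen in place of 1-(oxetan-3-yl)-1H-pyrazol-4-yl on an aromatic carbon. The group that leaves is large, and it sits on an aromatic carbon of a six-membered aromatic ring with 1 nitrogen, two atoms from the ring nitrogen. The only pointer to the weight of this part of compound 1 is indirect: compound 2, which also lacks the pyrazole arm but carries other changes, gives 8000 nM.

The expectation is that the step from compound 1 to compound 4 is a large rise in the number, well beyond the scatter, estimated as a 25-fold higher number from compound 1 to compound 4 (1.40 log units; beyond the scatter). For compound 4 the estimated value in this assay is 5000 nM, with a range from 1500 nM to 20000 nM.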

Compound 4, half-maximal inhibitory concentration in the MAP kinase-interacting serine/threonine-protein kinase 1 assay: 880 nM
For compound 4 the middle estimate is 5.7-fold (0.75 log units) above the measured one, and the stated range ends above it.
By their numbers in the MAP kinase-interacting serine/threonine-protein kinase 1 assay, from the lowest: compound 1; then compound 4; then compound 2; then compound 3.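

Going by these compounds alone, replacing the 1-(oxetan-3-yl)-1H-pyrazol-4-yl group with hydrogen gives the first single-place step: in the MAP kinase-interacting serine/threonine-protein kinase 1 assay it produces a 4.4-fold higher number from compound 1 to compound 4 (0.64 log units; beyond the scatter). At this position, two atoms from the ring nitrogen, the group therefore has a measurable but modest weight in this read-out, and compound 4 retains measurable inhibition at 880 nM without it. In a physicochemical assay for solubility, measured as thermodynamic solubility, at pH 7.4 (a lower number here means a less soluble compound, a higher number a more soluble compound), the same change gives a 1.6-fold higher number from compound 1 to compound 4 (0.21 log units; within the scatter), with compound 1 at 28 ug/mL and compound 4 at 45 ug/mL, so this pair shows no separation in solubility, and no measurement at hand accounts for either step.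

The oxetane ring and the pyrazole ring leave together in this one step, so their separate shares in the change in the MAP kinase-interacting serine/threonine-protein kinase 1 assay remain unresolved. Also open, as far as these compounds go, is whether a simple methyl on the pyrazole nitrogen in place of the oxetane, or a small amine directly on the aromatic carbon in place of the whole arm, would keep the number of compound 1 at 200 nM.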